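The source may hold more compounds than are shown below. What is called first, only, known or untested is meant among the compounds shown, and "the series" means these compounds.

Of the compounds shown here, three sharing one core have been measured in a functional assay on HCT-116 cells (Homo sapiens) for cytotoxicity, read by MTT assay, with a stated time of 72 h; a higher number here means a weaker inhibitor, a lower number a stronger inhibitor. Compound 2 `COc1ccc(/C=C2\S/C(=N\c3csc(-c4ccc(Cl)cc4)c3)NC2=O)cc1` stands lowest of the three, at 1300 nM. Compound 1 `O=C1N/C(=N/c2csc(-c3ccc(Cl)cc3)c2)S/C1=C\c1ccccc1` gives 11200 nM, and compound 3 `O=C1N/C(=N/c2csc(-c3ccc(Cl)cc3)c2)S/C1=C\c1ccccn1` gives 21600 nM. The two steps that separate compound 2 from its neighbours are an 8.6-fold lower number from compound 1 to compound 2 (0.94 log units; beyond the scatter) and a 17-fold higher number from compound 2 to compound 3 (1.22 log units; beyond the scatter); both reach beyond the usual scatter of this assay.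

Compound 4 `COc1ccc(/C=C2\S/C(=N\c3csc(-c4ccc(Cl)cc4)c3)NC2=O)cc1OC` is the next compound, not yet measured. It differs from compound 2 in one place: methoxy in place of hydrogen on an aromatic carbon. Among the compounds with values here, the only measured step that bears on this change is the earlier gain of a methoxy group, an 8.6-fold lower number from compound 1 to compound 2 (0.94 log units; beyond the scatter), which lowered the number. No measured compound carries two methoxy groups, so whether a second one adds to that effect, undoes it, or leaves it unchanged cannot be read from the data shown. The expectation is therefore a modest step at most: the number for compound 4 is estimated at 1000 nM, within 400 nM to 3000 nM, which would mean a 1.3-fold lower number from compound 2 to compound 4 (0.11 log units; within the scatter).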

Compound 4, half-maximal inhibitory concentration: 1700 nM
For compound 4 the middle estimate is 1.7-fold (0.23 log units) below the measured one, within the range that was stated.
By their numbers in this assay, from the lowest: compounds 2 and 4 (each within the scatter of the next); then compounds 1 and 3 (each within the scatter of the next).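

In this assay, a second methoxy group, placed ortho to the first and meta to a large group, gives no change that stands out from the scatter (a 1.3-fold higher number from compound 2 to compound 4 (0.12 log units; within the scatter)), so this place accepts the added group but the number does not follow it further down. The 3,4-dimethoxyphenyl group still stands clearly apart from plain phenyl (a 6.6-fold lower number from compound 1 to compound 4 (0.82 log units; beyond the scatter)) and from pyridin-2-yl (a 13-fold lower number from compound 3 to compound 4 (1.10 log units; beyond the scatter)), which shows that the gain seen with the first methoxy group survives the addition. Nothing measured here explains why the second methoxy group adds so little.

From the compounds shown here alone, it remains open whether a hydroxy group, an amine or a longer ethoxy chain at this same place would also leave the number unchanged. Also open, going by these compounds, is what a methoxy group at this place would give on its own, without the first one.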